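The compounds below may be only part of what the source reports. "The series", "measured", "known", "first", "only" and "open" are said of these compounds alone.

Working notes on the series. Going by the values given here, compound 2 `COc1cccc(-c2nn(Cc3ccc(NC(=O)OCCCCN(C)C)cc3)c(=O)c3ccccc23)c1` stands at the higher of the two numbers measured so far in an ADME assay on Huh-7 cells (Homo sapiens) for cytotoxicity, read by MTT assay, with a stated time of 48 h (a lower number here means that less compound is tolerated, a higher number that more compound is tolerated), where compound 2 gives 17600 nM. Its nearest neighbour is compound 1 `CN(C)CCCCOC(=O)Nc1ccc(Cn2nc(-c3ccccc3)c3ccccc3c2=O)cc1`, which in this assay gives 16000 nM; the step of a 1.1-fold higher number from compound 1 to compound 2 (0.04 log units; within the scatter) is within the scatter, so the two compounds are not separated on this read-out.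

The next compound, compound 3 `CN(C)CCCCOC(=O)Nc1ccc(Cn2nc(-c3cccc(C#N)c3)c3ccccc3c2=O)cc1`, differs from compound 2 by cyano in place of methoxy on an aromatic carbon. Among the compounds with values here, no measured step exchanges a methoxy for a cyano; the only step available, from compound 1 to compound 2, replaces hydrogen with methoxy on the same aromatic carbon and stays within the scatter. The data therefore give no basis for a shift in this assay beyond the scatter, in either direction, and the expected step of a 1.0-fold lower number from compound 2 to compound 3 (0.02 log units; within the scatter) is set accordingly as flat. On that basis compound 3 is estimated to give 17000 nM in this assay, with a range from 8000 nM to 36000 nM.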

Compound 3, half-maximal cytotoxic concentration: 17200 nM
Compound 3: the middle estimate sits 1.0-fold (0.01 log units) below what was measured; measured number inside the range.
By their numbers in this assay, from the lowest: compounds 1, 3 and 2 (each within the scatter of the next).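

In this assay, the exchange of 3-methoxyphenyl for 3-cyanophenyl gives a 1.0-fold lower number from compound 2 to compound 3 (0.01 log units; within the scatter) and so adds a second substituent at this aromatic carbon that is not separated from methoxy on this read-out. Against hydrogen on the same carbon, cyano gives a 1.1-fold higher number from compound 1 to compound 3 (0.03 log units; within the scatter) and so stands where methoxy stood in the earlier pair: hydrogen, methoxy and nitrile-bearing compounds all lie within the scatter of one another, whereas the earlier pair could show this for methoxy alone. Nothing at hand explains why these three compounds are not separated.

At this place the compounds shown carry only hydrogen, methoxy and cyano, so it remains open whether a larger or differently built substituent, such as an amine or a carboxylic acid, would also stay within the scatter. The side chain ending in the dimethylamino group is the same in compound 1, compound 2 and compound 3, which leaves open what a longer chain would give in this assay on the shared core.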